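Pyrrolyl to methylphenyl on the cyanoacrylamide chain

This account rests on a few compounds, and the source may have more. Where it says the series, first, only, none or still open, it means among the compounds named here.

Measured compounds:
compound 1 `COc1ccc(CNC(=O)/C(C#N)=C/c2ccc[nH]2)cc1` — > 50000 nM
compound 2 `N#C/C(=C\c1ccc[nH]1)C(=O)NCc1ccc(Cl)c(Cl)c1` — > 50000 nM

Two amides of the same cyanoacrylamide core were tested in a functional assay on A-431 cells (Homo sapiens) for inhibition, read by MTT assay, with a stated time of 72 h; on this read-out lower numbers stand for stronger inhibition of growth and higher numbers for weaker inhibition of growth. In this assay compound 1 gives > 50000 nM, which is a limit of the assay and not a number. Compound 2 in this assay likewise gives > 50000 nM, again a limit. Thus compound 1 stands at the limit, together with the only other value shown, (the limit of > 50000 nM in this assay, at which 2 of the 2 values shown sit). Going by the values given here, no step between measured compounds can be counted.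

Compound 3 `COc1ccc(CNC(=O)/C(C#N)=C/c2ccc(C)cc2)cc1` differs from compound 1 by 4-methylphenyl in place of 1H-pyrrol-2-yl on a double-bonded chain carbon bound to a double-bonded chain carbon. Since compound 1 sits at the limit, only a gain of potency large enough to bring compound 3 into the measurable range would show as a step beyond the scatter; no shown pair supports such a gain, so the step from compound 1 to compound 3 is expected to be a number no higher from compound 1 to compound 3 (the limit leaves the size open), that is none beyond the scatter. Compound 3 is accordingly estimated at 50000 nM, with a range of 10000 nM to 150000 nM, and most likely a limit once more.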

Compound 3, concentration for 50% growth inhibition: 26000 nM
For compound 3 the middle estimate is 1.9-fold (0.28 log units) above the measured one, and the stated range covers the measured number.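

Going by these compounds alone, the change of 1H-pyrrol-2-yl to 4-methylphenyl on a double-bonded chain carbon bound to a double-bonded chain carbon gives the first measurable number of the series in this assay, where compound 3 reads 26000 nM. This place on the shared core can therefore move the read-out off the limit, which the two amide variants did not show: the limit of > 50000 nM in this assay, at which 2 of the 3 values shown sit. The change gives an at least 1.9-fold lower number from compound 1 to compound 3 (0.28 log units; that floor lies within the scatter), so the step is known only as a floor, and it cannot be said to exceed the usual scatter.

The compounds shown leave open whether the methyl group or the swap of the ring itself accounts for the step, and how a plain phenyl, or a phenyl carrying a hydroxyl or an amine, would read at this place. They also leave open whether the same change would move compound 2 off its limit.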